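Compound 3: A Naphthalen-1-yl Swap at the Sulfonyl Sulfur

The source may report more compounds than this note shows. Statements on the series, on what has been measured and on what is new or still open speak of the compounds shown alone.

Compound 1 `COc1cc(-c2nc(-c3ccccc3)[nH]c2-c2ccnc(NCCCNS(=O)(=O)c3cccc(F)c3)n2)ccc1Cl` gives 5110 nM
Compound 2 `COc1ccc(S(=O)(=O)NCCCNc2nccc(-c3[nH]c(-c4ccccc4)nc3-c3ccc(Cl)c(OC)c3)n2)cc1` gives 1800 nM

Among the measured compounds shown here, in a functional assay on LOX IMVI cells (Homo sapiens) for cytotoxicity, read by MTT assay, with a stated time of 24 h (a lower number here means a stronger inhibitor, a higher number a weaker inhibitor), compound 2 gives 1800 nM, the lower of the two numbers measured so far. For the measured compounds named here, the only measured step is a 2.8-fold lower number from compound 1 to compound 2 (0.45 log units; beyond the scatter). That modest step, beyond the scatter, came with 4-methoxyphenyl in place of 3-fluorophenyl on a sulfonyl sulfur.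

Compound 3 `COc1cc(-c2nc(-c3ccccc3)[nH]c2-c2ccnc(NCCCNS(=O)(=O)c3cccc4ccccc34)n2)ccc1Cl` has not yet been measured. Its difference from compound 2 lies at that same place: naphthalen-1-yl in place of 4-methoxyphenyl on a sulfonyl sulfur. In words, naphthalen-1-yl stands in place of 4-methoxyphenyl on a sulfonyl sulfur. Going by the values given here, no measured compound carries naphthalen-1-yl, so the direction of the change is poorly defined. With only a 2.8-fold lower number from compound 1 to compound 2 (0.45 log units; beyond the scatter) as a guide, a change of similar modest size or smaller is expected in this assay, and most likely none beyond the scatter. The estimated step is a 1.2-fold higher number from compound 2 to compound 3 (0.09 log units; within the scatter), leaning slightly toward a weaker inhibitor. For compound 3 the expected value is 2200 nM, with an estimated range from 750 nM to 6500 nM.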

Compound 3, half-maximal inhibitory concentration: 13500 nM
Beside the measured number, compound 3's estimate is 6.1-fold (0.79 log units) below it, and the stated range ends below it.
By their numbers in this assay, from the lowest: compound 2; then compound 1; then compound 3.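

In this assay, the group on the sulfonyl sulfur proves able to move the number well beyond the scatter: naphthalen-1-yl in place of 4-methoxyphenyl gives a 7.5-fold higher number from compound 2 to compound 3 (0.88 log units; beyond the scatter), a larger step than the earlier 2.8-fold lower number from compound 1 to compound 2 (0.45 log units; beyond the scatter). The new group also falls short of 3-fluorophenyl, with a 2.6-fold higher number from compound 1 to compound 3 (0.42 log units; beyond the scatter), so compound 3 is the weakest of the three inhibitors here, and the two groups with one six-membered aromatic ring both give lower numbers than the group with two such rings. No measurement shown here accounts for this loss, and the reason for it remains unknown.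

The three compounds cannot separate the effect of the second aromatic ring from that of how the ring system is attached to the sulfur, a question that naphthalen-2-yl or an unsubstituted phenyl group on the sulfonyl sulfur would help address. Going by these compounds, it also remains open whether a small alkyl group such as methyl, or an aryl group carrying an amine or a carboxylic acid, would keep the number near that of compound 2 1800 nM.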